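The source may report more compounds than this note shows. Statements on the series, on what has been measured and on what is new or still open speak of the compounds shown alone.

Compounds measured so far:

Compound 1, `Cc1cccc(C)c1NC(=O)CSc1nnc(-c2ccoc2C)n1Cc1ccco1`. In a functional assay on CHO cells for antagonist activity at Orexin/Hypocretin receptor type 1 (Homo sapiens), read by FLIPR and calcium flux (a lower number here means a stronger inhibitor, a higher number a weaker inhibitor), compound 1 reached only the assay limit, > 15800 nM.

Compound 2, `Cc1cc(C)cc(N(C(=O)CSc2nnc(-c3ccoc3C)n2Cc2ccco2)c2ccccn2)c1`. In this assay compound 2 likewise reached only the assay limit, > 15800 nM.

Compound 2 therefore stands at the edge of what this assay can report: no number for it exists, only a limit, and the same is true of the other compound shown, so that (the limit of > 15800 nM in this assay, at which 2 of the 2 values shown sit). Nothing in these two results separates compound 2 from compound 1, and no pattern can be drawn from them.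

The next compound, compound 3, `Cc1cc(C)cc(N(C(=O)CSc2nnc(-c3ccoc3C)n2Cc2ccco2)C2CNCCN2)c1`, differs from compound 2 in one place: piperazin-2-yl in place of pyridin-2-yl on an amide-type nitrogen. Among the measured compounds shown here, since both measured compounds sit at the limit, there is no measured step to lean on. The expectation is that compound 3 will again fall at or beyond the limit, so the step that the limit leaves unreadable from compound 2 to compound 3 is expected to be none beyond the scatter. Compound 3 is estimated at 20000 nM, in the range 5000 nM to 60000 nM.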

Compound 3, inhibition constant: > 15800 nM
Compound 3: a limit, no number (the forecaster's own chance of this, stated with the estimate: 85%); the middle value does not contradict the limit.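

Compound 3, like compound 2, gives only a limit and not a number in this assay, so no step can be read for piperazin-2-yl in place of pyridin-2-yl: (the limit of > 15800 nM in this assay, at which 3 of the 3 values shown sit). The compounds shown leave open whether any close relative gives a true number in this assay and which changes would matter.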